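One Double Bond, Redrawn: From Compound 2 to Compound 3

A few compounds are considered here, and "the series" means these few. Any claim that something is new, unique, unknown or untested is made for them only; others in the source may bear on it.

Compound 1 `C/C(=N\NC(=S)Nc1ccc(I)cc1)c1ccccn1` gives 64 nM
Compound 2 `C/C(=N/NC(=S)Nc1ccc([N+](=O)[O-])cc1)c1ccccn1` gives 140 nM

In a functional assay on T98G cells (Homo sapiens) for cytotoxicity, read by MTT assay, with a stated time of 48 h (a lower number here means a stronger inhibitor, a higher number a weaker inhibitor), compound 2 gives 140 nM and so holds the higher of the two numbers. Its gap to compound 1 at 64 nM lies beyond the usual scatter.

The next structure to be tested is compound 3 `C/C(=N\NC(=S)Nc1ccc([N+](=O)[O-])cc1)c1ccccn1` and its relation to compound 2 is a matter of geometry alone (the two compounds have the same atoms and bonds and differ only in configuration as drawn: 1 of 1 stereo elements differ; a double bond is drawn Z in compound 2 and E in compound 3). The two compounds have the same atoms and bonds, and a double bond is drawn Z in compound 2 and E in compound 3.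

Among the compounds with values here, no measured pair here shows what such a change does, so the expectation has no direct precedent and stays cautious. The expected step of a 1.3-fold lower number from compound 2 to compound 3 (0.10 log units; within the scatter) is estimated to stay within the scatter, with no firm direction. The estimate for compound 3 is 110 nM in this assay with an expected range from 35 nM to 350 nM on repeated measurement.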

Compound 3, half-maximal inhibitory concentration: 140 nM
For compound 3 the middle estimate is 1.3-fold (0.10 log units) below the measured one; low and high end bracket the measured number.
By their numbers in this assay, from the lowest: compound 1; then compounds 2 and 3 (each within the scatter of the next).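

Measured in this assay the redrawn double bond gives no change at the digits printed from compound 2 to compound 3 (within the scatter) so, with the nitro group in place, this configuration leaves the read-out where it stood, and the comparison isolates that single element: the fact that compounds 2 and 3 differ only in the configuration as drawn.

The result also resolves what the first two compounds could not, since compound 1 and compound 2 differ in two places and their gap could be assigned to neither, whereas compound 1 and compound 3 differ in one place only. Read on that pair, nitro in place of iodo on an aromatic carbon gives a 2.2-fold higher number from compound 1 to compound 3 (0.34 log units; beyond the scatter) and so the substituent, not the double bond, accounts for the gap seen among these three compounds.

The compounds shown leave open whether the double bond would prove as indifferent with iodo on the aromatic carbon as it does with nitro, since only the nitro pair speaks to that. They also leave open how an amine or a carboxylic acid in that same place would compare with iodo and nitro, and whether the step between those two extends to any other substituent.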